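Dichlorophenyl urea variant of a thienopyrimidine series

This account rests on a few compounds, and the source may have more. Where it says the series, first, only, none or still open, it means among the compounds named here.

Compound 2 `CN(C)CCNc1nc(-c2ccc(NC(=O)Nc3ccccc3)cc2)nc2ccsc12` is one of three ureas sharing a core and measured in a functional assay on MKN-45 cells (Homo sapiens) for cytotoxicity, read by MTT assay, with a stated time of 72 h; on this read-out higher numbers stand for weaker inhibition and lower numbers for stronger inhibition. In this assay compound 2 gives 1120 nM. Compound 1 `CN(C)CCCNc1nc(-c2ccc(NC(=O)Nc3ccccc3Cl)cc2)nc2ccsc12`, which carries a chlorine on the terminal phenyl and a longer amine chain, gives 690 nM in this assay, and compound 3 `CN(C)CCNc1nc(-c2ccc(NC(=O)Nc3ccc(Cl)cc3)cc2)nc2c(Cl)c(Cl)sc12`, with a chlorinated phenyl and a chlorinated core, gives 910 nM. The number for compound 2 sits within the scatter of both compound 1 and compound 3, so the three cannot be told apart.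

Compound 4 `CN(C)CCNc1nc(-c2ccc(NC(=O)Nc3ccc(Cl)cc3Cl)cc2)nc2ccsc12` has not been measured. It differs from compound 2 in one place: 2,4-dichlorophenyl in place of phenyl on an amide-type nitrogen. Among the measured compounds shown here, no single-change step among the measured compounds shows what this exchange does. The chlorinated ureas, compound 1 and compound 3, give numbers within the scatter of compound 2, so a step of no more than the scatter is expected, and if anything toward a lower number. The step from compound 2 to compound 4 is therefore estimated at a 1.5-fold lower number from compound 2 to compound 4 (0.17 log units; within the scatter). For compound 4 a value of 750 nM is expected, between 320 nM and 1800 nM.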

Compound 4, half-maximal inhibitory concentration: 2360 nM
Estimate against measurement, compound 4: 3.1-fold (0.50 log units) below, and the stated range ends below it.
By their numbers in this assay, from the lowest: compounds 1, 3 and 2 (each within the scatter of the next); then compound 4.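

In this assay, among the compounds shown here, the exchange of phenyl for 2,4-dichlorophenyl on the amide-type nitrogen provides the first single-change step in this set, a 2.1-fold higher number from compound 2 to compound 4 (0.32 log units; beyond the scatter), a modest move toward weaker inhibition. Compound 1 and compound 3 also carry chlorine on the terminal phenyl, but each differs from compound 2 in more than one place, so neither could isolate this exchange; here, with the amine chain and the shared core held constant, the position is shown to respond to the change. Nothing available explains why the number rises.

From the compounds shown here alone, what remains open is whether either chlorine alone accounts for the step, or whether both are needed. Also open, going by these compounds, is how a pyridyl or cyclohexyl group on the same nitrogen would compare with phenyl.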